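Cyano for bromo on a pyridyl azetidinylmethyl ether

This account rests on a few compounds, and the source may have more. Where it says the series, first, only, none or still open, it means among the compounds named here.

Measured compounds:
- compound 1, `Cc1ccc(OC[C@@H]2CCN2)cn1`: 0.057 nM
- compound 2, `COc1ccc(OC[C@@H]2CCN2)cn1`: 1.3 nM
- compound 3, `Brc1cncc(OC[C@@H]2CCN2)c1`: 0.18 nM

Three compounds share a core in which an azetidine ring carries a methylene ether to a pyridine. In an assay on brain for binding affinity to Neuronal acetylcholine receptor; alpha4/beta2 (Rattus norvegicus), read by radioligand binding (a higher number here means a weaker inhibitor, a lower number a stronger inhibitor), compound 1 gives 0.057 nM and compound 2 gives 1.3 nM; the one step shown between them, a 23-fold higher number from compound 1 to compound 2 (1.36 log units; beyond the scatter), is large and goes with a methoxy in place of a methyl on an aromatic carbon. Compound 3 gives 0.18 nM and stands second highest of the three numbers, closer to compound 1 than to compound 2.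

Compound 4, `N#Cc1cncc(OC[C@@H]2CCN2)c1`, is not yet measured. It differs from compound 3 by cyano in place of bromo on an aromatic carbon. No measured step concerns the same kind of change: the only step shown swaps methyl for methoxy, and compounds 1, 2 and 3 offer no pair in which bromo gives way to cyano. The expectation for compound 4 therefore leans on the spread of the three numbers rather than on a matching precedent, and the estimated step of a 1.9-fold higher number from compound 3 to compound 4 (0.29 log units; within the scatter) is taken as modest, with the direction uncertain. Compound 4 is estimated at 0.35 nM, in a range from 0.08 nM to 1.5 nM.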

Compound 4, inhibition constant: 0.025 nM
Beside the measured number, compound 4's estimate is 14-fold (1.15 log units) above it; measured number below the stated range.
By their numbers in this assay, from the lowest: compound 4; then compound 1; then compound 3; then compound 2.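

At this aromatic carbon, two atoms from the ring nitrogen, replacing bromo with cyano gives a 7.2-fold lower number from compound 3 to compound 4 (0.86 log units; beyond the scatter) in this assay, so a two-heavy-atom group carrying a triple bond and one hydrogen-bond acceptor is not merely accepted at this position but goes with a clearly stronger inhibitor than the single bromine. For the compounds shown here, the earlier compounds could not show this, since their one step, a 23-fold higher number from compound 1 to compound 2 (1.36 log units; beyond the scatter), concerns methyl and methoxy, runs towards a weaker inhibitor and says nothing about this position or about either group exchanged here. Nothing shown here accounts for the gain, and the size of the step is all that can be stated.

Going by these compounds, whether the lower number belongs to cyano in particular or would also come with other groups at this carbon remains open, and an amine, a carboxylic acid or a longer chain such as ethynyl in the same place would be needed to tell. Also open is whether the exchange of bromo for cyano would give a step of similar size elsewhere on the ring, since the compounds shown hold that change at one place only.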